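The source may report more compounds than this note shows. Statements on the series, on what has been measured and on what is new or still open speak of the compounds shown alone.

- Compound 1 (`O=C(NCc1ccc(S(=O)(=O)c2ccccc2)cc1)N1Cc2ccncc2C1`) gives 7.5 mL/min/kg
- Compound 2 (`O=C(NCc1ccc(S(=O)(=O)C2CCOCC2)cc1)N1Cc2ccncc2C1`) gives 6 mL/min/kg

These numbers come from an ADME assay on microsomes from liver (Homo sapiens) for pharmacokinetics, read by LC-MS, with a stated time of 60 min, tested at 1 uM (a higher number here means faster removal of the compound, a lower number slower removal), and compound 2, at 6 mL/min/kg here, sits level with compound 1 within the usual scatter. Among the compounds with values here, compound 3 (`CCC(=O)N1CCC(S(=O)(=O)c2ccc(CNC(=O)N3Cc4ccncc4C3)cc2)CC1`) has 1-propanoylpiperidin-4-yl in place of oxan-4-yl on a sulfonyl sulfur as its one difference from compound 2. Within the data shown here, only one measured step bears on this, a swap on the same sulfur (a 1.3-fold lower number from compound 1 to compound 2 (0.10 log units; within the scatter)) that stayed within the scatter. Among the measured compounds shown here, no measured compound carries the propanoyl group, so the expectation is loose, and no shift beyond the scatter is expected in this assay at this point. The expected step is small (a 1.3-fold higher number from compound 2 to compound 3 (0.12 log units; within the scatter)) on this evidence. Compound 3 is estimated at 8 mL/min/kg with a range of 4.5 mL/min/kg to 14 mL/min/kg as the expected span.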

Compound 3, clearance: 11 mL/min/kg
Compound 3: middle estimate off by 1.4-fold (0.14 log units), on the low side; the range from low to high includes it.
By their numbers in this assay, from the lowest: compounds 2, 1 and 3 (each within the scatter of the next).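

At the sulfonyl sulfur in this assay, the larger 1-propanoylpiperidin-4-yl group also stays within the scatter of both earlier groups (oxan-4-yl: a 1.8-fold higher number from compound 2 to compound 3 (0.26 log units; within the scatter); phenyl: a 1.5-fold higher number from compound 1 to compound 3 (0.17 log units; within the scatter)). This place therefore now accepts an aromatic ring, a simple non-aromatic ring and a ring carrying a propanoyl group with no clear change in the clearance number. Nothing available explains this result. On these data alone, whether a free amine or a carboxylic acid in place of the propanoyl group would also stay within the scatter remains open.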